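Replacing a Chloro by Methyl on a Very Soluble Acid

This account rests on a few compounds, and the source may have more. Where it says the series, first, only, none or still open, it means among the compounds named here.

Measured so far:
compound 1, `O=C(O)c1ccc(-n2cc(C(=O)c3c(Cl)cccc3Cl)c3cccnc32)cc1`, 407000 nM in a physicochemical assay for solubility, at pH 7.4; on this read-out higher numbers stand for higher solubility and lower numbers for lower solubility
compound 2, `O=C(O)c1ccc(-n2cc(C(=O)c3c(Cl)cccc3Cl)c3cccnc32)c(F)c1`, > 2000000 nM

Compound 2 gives only a limit in this assay, > 2000000 nM, so its solubility is known to lie at or past the top of what the method reports (the limit of > 2000000 nM in this assay, at which 1 of the 2 values shown sits). Compound 1, the matching compound without the fluoro, gives 407000 nM, and the change from hydrogen to fluoro was an at least 4.9-fold higher number from compound 1 to compound 2 (0.69 log units; beyond the scatter).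

Compound 3, `Cc1cccc(Cl)c1C(=O)c1cn(-c2ccc(C(=O)O)cc2F)c2ncccc12`, keeps the fluoro of compound 2 and differs only as follows: methyl in place of chloro on an aromatic carbon. Among the compounds with values here, the one measured step concerns a fluoro, not a methyl in place of chloro, so no measured step bears on this change. Without such a step, the expectation is for no step beyond the scatter, a number no higher from compound 2 to compound 3 (the limit leaves the size open), and compound 3 is therefore estimated at 2000000 nM in this assay, with a likely range from 700000 nM to 4000000 nM.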

Compound 3, solubility: 1960000 nM
Beside the measured number, compound 3's estimate is 1.0-fold (0.01 log units) above it; the measured number falls inside the stated range.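

Methyl in place of chloro, which turns 2,6-dichlorophenyl into 2-chloro-6-methylphenyl, is a change the earlier compounds did not touch, and in this assay it gives an at least 1.0-fold lower number from compound 2 to compound 3 (0.00 log units; that floor lies within the scatter). Compound 2 gives > 2000000 nM, which is a limit and not a number. Compound 3 gives 1960000 nM, a number that can be read, so the swap keeps this compound high on the read-out. The true size of the step stays unknown because one end of it is a limit: the limit of > 2000000 nM in this assay, at which 1 of the 3 values shown sits.

The compounds shown leave open how the same swap reads on compound 1, which lacks the fluoro and does not sit at the limit. They also leave open how an ethyl or a methoxy would read in place of the methyl.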